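Methoxy in Place of the (Dimethylamino)methyl Group

The compounds below may be only part of what the source reports. "The series", "measured", "known", "first", "only" and "open" are said of these compounds alone.

Measured compounds:
compound 1, `O=C(O)CCc1ccc(NCc2ccc(-c3ccccc3)cc2)cc1`, 251 nM
compound 2, `CN(C)Cc1ccc(CNc2ccc(CCC(=O)O)cc2)cc1`, < 31700 nM

In a functional assay for agonist activity at Free fatty acid receptor 1 (Homo sapiens) (a lower number here means that less compound is needed, a higher number that more compound is needed for the effect), compound 1 gives 251 nM. For compound 2, this assay yields only a limit, < 31700 nM, not a number; it sits at the limit of < 31700 nM in this assay, at which 1 of the 2 values shown sits. The step that the limit leaves unreadable from compound 1 to compound 2 therefore cannot be read, and compound 2 stands only at that limit, with no value of its own.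

Compound 3, `COc1ccc(CNc2ccc(CCC(=O)O)cc2)cc1`, has not been measured in this assay. It differs from compound 2 by methoxy in place of (dimethylamino)methyl on an aromatic carbon. Going by the values given here, no measured step bears on this change: the only step available, from compound 1 to compound 2, is unreadable, so the size of the change expected from the replacement cannot be drawn from the data. Among the compounds with values here, what is known is that the one compound with a number, compound 1, carries a phenyl at this position.

Compound 3 is estimated at 6000 nM, between 1000 nM and 31700 nM, and the step that the limit leaves unreadable from compound 2 to compound 3 is accordingly an estimate and nothing more.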

Compound 3, half-maximal effective concentration: 1260 nM
Estimate against measurement, compound 3: 4.8-fold (0.68 log units) above; the measured number falls inside the stated range.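

Compound 3 gives this position its first readable comparison, with a 5.0-fold higher number from compound 1 to compound 3 (0.70 log units; beyond the scatter) in this assay when methoxy stands in place of phenyl on an aromatic carbon. The phenyl is therefore not required for a measured number in this assay, although its replacement by methoxy gives a modest step beyond the scatter. The steps that involve compound 2 still cannot be read, and the change from (dimethylamino)methyl to methoxy stays without a size, as compound 2 has only a limit: the limit of < 31700 nM in this assay, at which 1 of the 3 values shown sits.

The compounds shown leave open how an ethoxy or a butoxy chain on this aromatic carbon would compare with methoxy and phenyl. A single readable step also cannot tell which feature of the phenyl accounts for the difference.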